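Tert-butyl ester on the thiophene-bearing compound

A few compounds are considered here, and "the series" means these few. Any claim that something is new, unique, unknown or untested is made for them only; others in the source may bear on it.

Measured compounds:
Compound 1, `CC1=C(C(=O)OC(C)(C)C)C(c2ccco2)NC(=S)N1`, gives 9% in an assay on membranes from HEK293 cells for displacement of a labelled ligand from adenosine receptor A2b (Homo sapiens), read by scintillation counting, with a stated time of 30 min, tested at 1 uM; a lower number here means less inhibition, a higher number more inhibition at the concentration tested (going by the name of the read-out).
Compound 2, `CCCOC(=O)C1=C(C)NC(=S)NC1c1ccsc1`, gives 26% in this assay.
Compound 3, `CC1=C(C(=O)OCC(C)C)C(c2ccsc2)NC(=S)N1`, gives 15% in this assay.

Compound 3 stands second highest of the three numbers: within the scatter of compound 1, and beyond the scatter below compound 2. Compound 4, `CC1=C(C(=O)OC(C)(C)C)C(c2ccsc2)NC(=S)N1`, differs from compound 3 by tert-butyl in place of isobutyl on an oxygen next to a carbonyl group. Among the compounds with values here, the one measured step, a number 11 percentage points lower from compound 2 to compound 3 (beyond the scatter), also alters the ester chain, yet not with this exchange, so it bears on it only loosely. Compound 1 carries the same tert-butyl group with a different ring and gives 9%, within the scatter of compound 3. No step beyond the scatter is therefore expected: the estimated change is a number 3 percentage points lower from compound 3 to compound 4 (within the scatter). Compound 4 is expected to give 12%, between 2% and 25%.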

Compound 4, a percentage reported as inhibition, at one concentration (the size of the read-out at that concentration, not a potency): 26%
For compound 4 the middle estimate is 14 percentage points below the measured one; the measured number lies above the stated range.
By their numbers in this assay, from the lowest: compounds 1 and 3 (each within the scatter of the next); then compounds 2 and 4 (each within the scatter of the next).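

On the oxygen next to a carbonyl group, the shape of the ester chain counts: tert-butyl in place of isobutyl gives a number 11 percentage points higher from compound 3 to compound 4 (beyond the scatter) even though the two groups hold the same atoms. Tert-butyl in place of propyl shows no change at the digits printed from compound 2 to compound 4 (within the scatter) so the isobutyl ester of compound 3 stands apart from both. The ring counts too, with thiophen-3-yl in place of furan-2-yl giving a number 17 percentage points higher from compound 1 to compound 4 (beyond the scatter) at the same tert-butyl ester. As far as these compounds go, whether a longer chain or an amide at this ester position would keep this level of inhibition stays open. No supporting data explain these steps.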